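This account rests on a few compounds, and the source may have more. Where it says the series, first, only, none or still open, it means among the compounds named here.

Measured so far in a functional assay (aorta) with Rattus norvegicus as the target; on this read-out lower numbers stand for an effect already at smaller amounts and higher numbers for an effect only at larger amounts of compound:
Compound 1 `CC1(C)CC(NC(=O)Nc2ccccc2)c2cc(Cl)ccc2O1` gives 7800 nM.
Compound 2 `COc1ccc(NC(=O)NC2CC(C)(C)Oc3ccc(Cl)cc32)cc1` gives only a limit of the assay, > 30000 nM.
Compound 3 `Cc1ccc(NC(=O)NC2CC(C)(C)Oc3ccc(Cl)cc32)cc1` also gives only a limit of the assay, > 30000 nM.

Compound 3 stands at the upper edge of the numbers shown, sharing that edge with compound 2 (the limit of > 30000 nM in this assay, at which 2 of the 3 values shown sit). Compound 4 `CC1(C)CC(NC(=O)Nc2ccccc2Cl)c2cc(Cl)ccc2O1` differs from compound 3 by 2-chlorophenyl in place of 4-methylphenyl on an amide-type nitrogen. Among the measured compounds shown here, no measured step covers a chlorine on this ring. The nearest steps both start from the unsubstituted ring of compound 1: an at least 3.8-fold higher number from compound 1 to compound 2 (0.58 log units; beyond the scatter) and an at least 3.8-fold higher number from compound 1 to compound 3 (0.58 log units; beyond the scatter), while a step that the two limits leave unreadable from compound 2 to compound 3. Both substituted rings moved away from compound 1 in this assay, so compound 4 is expected to stay close to compound 3, giving an at least 1.5-fold lower number from compound 3 to compound 4 (0.17 log units; that floor lies within the scatter). Compound 4 is estimated at 20000 nM, within 5000 nM to 60000 nM.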

Compound 4, half-maximal effective concentration: > 300000 nM
Compound 4: no number, only a limit; the forecaster's own chance of this, stated with the estimate: 40%; middle value at least 15-fold (1.17 log units) from the limit.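

In this assay, a chlorine on the phenyl ring also moves the read-out away from the unsubstituted ring, so the change is not confined to methyl and methoxy: an at least 38-fold higher number from compound 1 to compound 4 (1.58 log units; beyond the scatter). Compound 4 gives only a limit of the assay: the limit of > 300000 nM in this assay, at which 1 of the 4 values shown sits. The steps from compound 2 and from compound 3 to compound 4 join two limits and cannot be read.

The compounds shown do not separate the chlorine itself from its place on the ring. On these data alone, what an amine or a carboxylic acid on this ring would give also stays open.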